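Working notes: extra methoxy on the carbonyl-side aryl group

This account rests on a few compounds, and the source may have more. Where it says the series, first, only, none or still open, it means among the compounds named here.

Measured compounds:
compound 1, `COc1cc(-c2cc(/C=C/C(=O)c3ccc(N)cc3)[nH]n2)cc(OC)c1OC`, gives 1850 nM in a functional assay on HT-29 cells (Homo sapiens) for inhibition, read by sulforhodamine B assay, with a stated time of 48 h; a lower number here means a stronger inhibitor of growth, a higher number a weaker inhibitor of growth.
compound 2, `COc1cc(-c2cc(/C=C/C(=O)c3ccc(Cl)c(Cl)c3)[nH]n2)cc(OC)c1OC`, gives 1150 nM in this assay.
compound 3, `COc1ccc(C(=O)/C=C/c2cc(-c3cc(OC)c(OC)c(OC)c3)n[nH]2)cc1OC`, gives 1620 nM in this assay.

The three numbers lie close together. For compound 3 the steps to the others are a 1.1-fold lower number from compound 1 to compound 3 (0.06 log units; within the scatter) and a 1.4-fold higher number from compound 2 to compound 3 (0.15 log units; within the scatter), both within the scatter, so compound 3 cannot be set apart from compound 1 or compound 2 on these data.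

Compound 4, `COc1cc(C(=O)/C=C/c2cc(-c3cc(OC)c(OC)c(OC)c3)n[nH]2)cc(OC)c1OC`, differs from compound 3 by methoxy in place of hydrogen on an aromatic carbon. Going by the values given here, no measured step adds or removes a single substituent on that aryl group; the measured steps instead exchange the whole group on the carbonyl carbon, and all of them stayed within the scatter: a 1.6-fold lower number from compound 1 to compound 2 (0.21 log units; within the scatter), a 1.1-fold lower number from compound 1 to compound 3 (0.06 log units; within the scatter) and a 1.4-fold higher number from compound 2 to compound 3 (0.15 log units; within the scatter). Since even those larger exchanges left this assay unmoved beyond the scatter, the smaller change from compound 3 to compound 4 is expected to give no step beyond the scatter, a 1.0-fold lower number from compound 3 to compound 4 (0.01 log units; within the scatter). Compound 4 is therefore estimated at 1600 nM, with a range of 700 nM to 3600 nM.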

Compound 4, concentration for 50% growth inhibition: 1790 nM
Beside the measured number, compound 4's estimate is 1.1-fold (0.05 log units) below it; measured number inside the range.
By their numbers in this assay, from the lowest: compounds 2, 3, 4 and 1 (each within the scatter of the next).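

Methoxy in place of hydrogen on an aromatic carbon, ortho to a methoxy group, gives a 1.1-fold higher number from compound 3 to compound 4 (0.04 log units; within the scatter) in this assay. Among the steps shown, this is the only one that changes a single substituent on the carbonyl-side aryl group rather than exchanging the whole group, and this position accepts the added methoxy without a shift that can be told from the scatter. No measurement is available that would explain this result.

Open, on these data alone, is whether a group of another kind at this position, such as an amine, a carboxylic acid or a longer alkoxy chain, would move the number beyond the scatter. Also open, as far as these compounds go, is whether a change to the core of compound 4, rather than to this aryl group, would do so.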